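The compounds below may be only part of what the source reports. "The series", "measured", "known", "first", "only" and "open" are said of these compounds alone.

Measured so far in a functional assay (Cavia porcellus) with sulfonylurea receptors; K-ATP channels (Homo sapiens) as the target; a higher number here means a weaker inhibitor, a lower number a stronger inhibitor:

- compound 1, `CC(O)(C(=O)Nc1ccc(S(=O)(=O)c2ccccc2C#N)cc1)C(F)(F)F`: 1100 nM
- compound 2, `CC(O)(C(=O)Nc1ccc(C(=O)c2ccccc2F)cc1)C(F)(F)F`: 2300 nM
- compound 3, `CC(O)(C(=O)Nc1ccc(C(=O)c2ccccc2)c(O)c1)C(F)(F)F`: 4200 nM

Compound 1 holds the lowest number of the three, and its gaps to compound 2 and to compound 3 are both beyond the scatter, so within this small set compound 1 is the strongest inhibitor. For the measured compounds named here, compound 2 and compound 3 each carry a carbonyl in place of the sulfonyl of compound 1 and differ from it in more than one place, so no single step between measured compounds is available to calibrate the change that follows.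

The next compound, compound 4 `CC(O)(C(=O)Nc1ccc(S(=O)(=O)c2cnccn2)cc1)C(F)(F)F`, keeps the core of compound 1 and alters only the group on the sulfonyl sulfur: pyrazin-2-yl in place of 2-cyanophenyl on a sulfonyl sulfur. Going by the values given here, no measured pair shows this kind of exchange, so the size of the step is open. A modest move toward a higher number, at most just beyond the scatter, is the working expectation for the step in this assay from compound 1 to compound 4, a 1.8-fold higher number from compound 1 to compound 4 (0.26 log units; within the scatter). For compound 4 the estimate in this assay is therefore 2000 nM, expected to fall between 600 nM and 7000 nM.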

Compound 4, half-maximal inhibitory concentration: 12000 nM
Compound 4: the middle estimate sits 6.0-fold (0.78 log units) below what was measured; the measured number lies above the stated range.
By their numbers in this assay, from the lowest: compound 1; then compounds 2 and 3 (each within the scatter of the next); then compound 4.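

For the compounds shown here, at this place, on a sulfonyl sulfur, the group matters a great deal: in this assay, pyrazin-2-yl in place of 2-cyanophenyl gives an 11-fold higher number from compound 1 to compound 4 (1.04 log units; beyond the scatter), the first step that can be read at a single place. A six-membered aromatic ring stays on the sulfur through this exchange, so the presence of such a ring alone does not preserve the inhibition seen with compound 1.

The exchange removes the nitrile and brings two hetero atoms into the ring together, and the compounds shown do not separate these changes, so it remains open how an unsubstituted phenyl or a pyridin-2-yl on the sulfonyl sulfur would read. Nothing at hand bears on the cause of this step.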